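Adding a chloro group to compound 2

The compounds below may be only part of what the source reports. "The series", "measured", "known", "first", "only" and "open" are said of these compounds alone.

Compound 1 (`O=C(CCCCC1CCSS1)Nc1ccccc1Cl`) gives 6.83%
Compound 2 (`O=C(CCCCC(S)CCS)Nc1ccccc1`) gives 0.85%

Among the compounds with values here, in a functional assay on Bel-7402 cells (Homo sapiens) for inhibition, read by MTT assay, with a stated time of 24 h, tested at 0.1 ug/mL (on this read-out lower numbers stand for less inhibition of growth and higher numbers for more inhibition of growth at the one concentration tested), compound 2 stands at 0.85% and lies within the usual scatter of compound 1, the only other compound measured so far. These two compounds differ in more than one place, so the pair isolates no single structural change.

Compound 3 (`O=C(CCCCC(S)CCS)Nc1ccccc1Cl`) is compound 2 with one change (chloro in place of hydrogen on an aromatic carbon): chloro in place of hydrogen on an aromatic carbon, ortho to a large group. Within the data shown here, no measured step shows what this change does on its own. Compound 1 also carries the chloro group, and compound 1 at 6.83% remains within the scatter of compound 2 at 0.85% on this read-out. No step beyond the scatter is therefore expected in this assay, though a slight move toward more inhibition of growth is possible. The expected change is a number 4.2 percentage points higher from compound 2 to compound 3 (within the scatter) and stays inside the scatter. For compound 3 the estimated value is 5% (range 0% to 15%).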

Compound 3, percent growth inhibition at one concentration: 5.11%
For compound 3 the middle estimate is 0.1 percentage points below the measured one; the range from low to high includes it.
By their numbers in this assay, from the lowest: compounds 2, 3 and 1 (each within the scatter of the next).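

In this assay, chloro in place of hydrogen on an aromatic carbon, ortho to a large group, now has a measured step of its own, and that step is a number 4.3 percentage points higher from compound 2 to compound 3 (within the scatter), so at this position the change does not separate the two compounds on this read-out. With the chloro group present on both sides, the open group of 5 heavy atoms can also be set against the five-membered non-aromatic ring with 2 hetero atoms, and that step is a number 1.7 percentage points lower from compound 1 to compound 3 (within the scatter), so this change likewise produces no difference that can be told from the scatter. No independent evidence is available to explain either result.

The compounds shown leave open whether a methoxy or nitro group in the same place on the aromatic ring would give a step beyond the scatter, and whether a longer chain between the carbonyl and the sulfur-bearing group would do so. Because all three compounds were read at one concentration, they also leave open whether the chloro group or the ring would make a difference at higher concentrations.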